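Replacing the Dimethylamino Group with an Ortho Chloro Substituent

The source may report more compounds than this note shows. Statements on the series, on what has been measured and on what is new or still open speak of the compounds shown alone.

The shared core carries two 4-hydroxy-3-methoxyphenyl-bearing alkenyl arms and a thiourea ring, with an aryl group on a saturated ring carbon. Compound 1 `COc1cc(/C=C/C(=O)C2=C(/C=C/c3ccc(O)c(OC)c3)NC(=S)NC2c2ccccc2)ccc1O` gives 38% in a functional assay, with a stated time of 20 min, tested at 20 uM; a higher number here means a stronger effect of the compound at the concentration tested, a lower number a weaker effect. Compound 2 `COc1cc(/C=C/C(=O)C2=C(/C=C/c3ccc(O)c(OC)c3)NC(=S)NC2c2ccc(C)cc2)ccc1O` gives 51%, and compound 3 `COc1cc(/C=C/C(=O)C2=C(/C=C/c3ccc(O)c(OC)c3)NC(=S)NC2c2ccc(N(C)C)cc2)ccc1O` gives 83%; compound 3 stands highest of the three, and its margin over both others is beyond the scatter. The steps are a number 13 percentage points higher from compound 1 to compound 2 (beyond the scatter), a number 45 percentage points higher from compound 1 to compound 3 (beyond the scatter) and a number 32 percentage points higher from compound 2 to compound 3 (beyond the scatter).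

Compound 4 `COc1cc(/C=C/C(=O)C2=C(/C=C/c3ccc(O)c(OC)c3)NC(=S)NC2c2ccccc2Cl)ccc1O` differs from compound 3 by 2-chlorophenyl in place of 4-(dimethylamino)phenyl on a saturated ring carbon. Within the data shown here, the steps that bear on this are those into compound 3, since compound 4 gives up the dimethylamino group: a number 45 percentage points higher from compound 1 to compound 3 (beyond the scatter) and a number 32 percentage points higher from compound 2 to compound 3 (beyond the scatter). Among the measured compounds shown here, no measured compound carries chlorine, so the effect of the 2-chlorophenyl itself is unknown; the expectation rests on the loss of the group that gave compound 3 its lead. Compound 4 is therefore expected to fall by a number 43 percentage points lower from compound 3 to compound 4 (beyond the scatter), landing near compound 1, with an estimate of 40% and a range from 22% to 60%.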

Compound 4, a percentage reported as activity, at one concentration (the size of the read-out at that concentration, not a potency): 56.6%
For compound 4 the middle estimate is 16.6 percentage points below the measured one; the measured number falls inside the stated range.
By their numbers in this assay, from the lowest: compound 1; then compounds 2 and 4 (each within the scatter of the next); then compound 3.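

At this saturated ring carbon, an aryl group without the dimethylamino group can still raise the read-out in this assay: the move from plain phenyl to 2-chlorophenyl gives a number 18.6 percentage points higher from compound 1 to compound 4 (beyond the scatter) and so keeps part of the gain, while 2-chlorophenyl in place of 4-(dimethylamino)phenyl gives a number 26.4 percentage points lower from compound 3 to compound 4 (beyond the scatter) and so leaves compound 3 clear of all the others. Set against 4-methylphenyl, 2-chlorophenyl gives a number 5.6 percentage points higher from compound 2 to compound 4 (within the scatter) and thus cannot be told apart from it here. No evidence bears on what lies behind these differences.

Going by these compounds, whether the gain in compound 4 belongs to chlorine itself or to where it sits stays open. Also open, on these data alone, is how a methoxy group, a fluoro group or a morpholine on the aromatic ring would compare with the dimethylamino group of compound 3.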